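The compounds below may be only part of what the source reports. "The series", "measured", "known", "first", "only" and "open" are said of these compounds alone.

Measured so far in an ADME assay on microsomes from liver (Rattus norvegicus) for metabolic stability; a lower number here means that the compound disappears faster, a higher number that the compound lasts longer:
compound 1 `CCn1ncc2c(F)cc(-c3ccc(C(CC)(CC)c4nnc(C)[nH]4)c(=O)[nH]3)cc21`: > 3 h
compound 2 `CC(C)C(/C=C1/CCNC1=O)c1ccc(-c2ccc3cccc(F)c3c2)[nH]c1=O`: 0.06 h
compound 3 `CCC(CC)(c1nnc[nH]1)c1ccc(-c2ccc3cccc(F)c3c2)[nH]c1=O`: 0.925 h

The value of compound 1 is a limit of the assay, not a number; it sits at the limit of > 3 h in this assay, at which 1 of the 3 values shown sits. Compound 2 and compound 3 give numbers and are the only measured points of reference. Compound 4 `CCn1ncc2c(F)cc(-c3ccc(C(CC)(CC)c4nncn4C)c(=O)[nH]3)cc21` has the same atoms as compound 1, joined differently: 4-methyl-4H-1,2,4-triazol-3-yl in place of 5-methyl-4H-1,2,4-triazol-3-yl on a saturated chain carbon bound to an aromatic carbon and two saturated chain carbons. No measured pair shows this swap, so no size for it is known and no cause can be given. The expected step of an at least 1.2-fold lower number from compound 1 to compound 4 (0.07 log units; that floor lies within the scatter) in this assay is within the scatter or at most a modest loss. Compound 4 is expected to give 2.5 h, in the range 1 h to 6 h, possibly again reported only as a limit.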

Compound 4, half-life: > 3 h
Compound 4: only a limit was reported (the forecaster's own chance of this, stated with the estimate: 40%); middle value at least 1.2-fold (0.07 log units) from the limit.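

In this assay, for the compounds shown here, compound 1 and compound 4 both end at a limit, so no step between them can be read: the limit of > 3 h in this assay, at which 2 of the 4 values shown sit. From the compounds shown here alone, whether 4-methyl-4H-1,2,4-triazol-3-yl in place of 5-methyl-4H-1,2,4-triazol-3-yl changes the half-life at all, and by how much, stays open.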